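Aryl amine swap on the shared core: propyl to acetyl

This account rests on a few compounds, and the source may have more. Where it says the series, first, only, none or still open, it means among the compounds named here.

Compound 1 `O=C1CCC(N2C(=O)c3ccc(Nc4ccccn4)cc3C2=O)C(=O)N1` and compound 2 `CCCc1ccc(Nc2ccc3c(c2)C(=O)N(C2CCC(=O)NC2=O)C3=O)cc1` share one core and differ only in the aryl group carried on the nitrogen. In an assay on FRT-Jurkat cells for inhibition of nuclear factor NF-kappa-B complex (Homo sapiens), read by flow cytometry, with a stated time of 24 h, tested at 10 uM (a higher number here means more inhibition at the concentration tested (going by the name of the read-out), a lower number less inhibition), compound 1 gives 9%. In this assay compound 2 gives 10%. Among the measured compounds shown here, the only measured step, a number 1 percentage points higher from compound 1 to compound 2 (within the scatter), lies within the scatter, so the two values cannot be ordered. For the measured compounds named here, compound 2 holds the higher of the two numbers, but its only neighbour, compound 1, sits within the scatter of it, so no ranking follows.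

Compound 3 `CC(=O)c1ccc(Nc2ccc3c(c2)C(=O)N(C2CCC(=O)NC2=O)C3=O)cc1` is not yet measured and is related to compound 2 by acetyl in place of propyl on an aromatic carbon. Going by the values given here, no measured step bears directly on this change: the step from compound 1 to compound 2 exchanges the whole aryl group rather than a substituent on it, and that step was itself within the scatter. With both measured numbers low and close together, no step beyond the scatter is expected in this assay. For compound 3 the expected step is no change at the digits printed from compound 2 to compound 3 (within the scatter). Compound 3 is estimated at 10% in this assay, with a range from 0% to 25%.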

Compound 3, a percentage reported as inhibition, at one concentration (the size of the read-out at that concentration, not a potency): -2%
For compound 3 the middle estimate is 12 percentage points above the measured one, and the stated range ends above it.
By their numbers in this assay, from the lowest: compound 3; then compounds 1 and 2 (each within the scatter of the next).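

In this assay, among the compounds shown here, the aromatic carbon para to a large group is the first place where a change registers: acetyl in place of propyl gives a number 12 percentage points lower from compound 2 to compound 3 (beyond the scatter), although both groups have the same heavy-atom count and only acetyl brings a double bond outside aromatic rings and a hydrogen-bond acceptor. Exchange of the whole aryl group can also register, depending on the aryl group that enters: 4-acetylphenyl in place of pyridin-2-yl gives a number 11 percentage points lower from compound 1 to compound 3 (beyond the scatter), whereas 4-propylphenyl in place of pyridin-2-yl gave a number 1 percentage points higher from compound 1 to compound 2 (within the scatter). No measurement shown here accounts for the step.

As far as these compounds go, whether an amine, a carboxylic acid or a longer chain in the same place would read like acetyl or like propyl stays open, and with it whether the step tracks the carbonyl or the acetyl group as a whole. For the compounds shown here, also open is whether any substituent at this position lifts the number clearly beyond that of compound 2 at 10%, since the steps so far span only low numbers at a single concentration.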